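Removing a fluorine from the central ring: what to expect

The compounds below may be only part of what the source reports. "The series", "measured", "known", "first", "only" and "open" are said of these compounds alone.

Measured compounds in a functional assay on PC-3 cells (Homo sapiens) for cytotoxicity, read by MTT assay, with a stated time of 72 h; on this read-out lower numbers stand for stronger inhibition and higher numbers for weaker inhibition:
- compound 1 `Cc1c(C(=O)Nc2ccc(Oc3ccnc4[nH]ccc34)c(F)c2)nnn1-c1ccccc1F`: 3240 nM
- compound 2 `COc1ccc(-n2nnc(C(=O)Nc3ccc(Oc4ccnc5[nH]ccc45)c(F)c3)c2C)cc1`: "not determined" (no result reported)
- compound 3 `Cc1c(C(=O)Nc2ccc(Oc3ccnc4[nH]ccc34)c(F)c2)nnn1-c1ccc(F)c(F)c1`: 6540 nM

Compound 1 has the lowest number of the two reported; its nearest neighbour is compound 3, reached by a 2.0-fold higher number from compound 1 to compound 3 (0.31 log units; beyond the scatter). Compound 2 has no result.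

Compound 4 `Cc1c(C(=O)Nc2ccc(Oc3ccnc4[nH]ccc34)cc2)nnn1-c1ccccc1F` differs from compound 1 by hydrogen in place of fluoro on an aromatic carbon. Going by the values given here, no measured step touches this ring: the only step, from compound 1 to compound 3, alters the group on the aromatic nitrogen instead, so it offers no direct guide. With nothing pointing either way, no change beyond the scatter is expected in this assay, and the step of a 1.1-fold higher number from compound 1 to compound 4 (0.03 log units; within the scatter) is the estimate. Compound 4 is therefore expected at 3500 nM, within 1400 nM to 9000 nM.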

Compound 4, half-maximal inhibitory concentration: 3450 nM
Compound 4: middle estimate off by 1.0-fold (0.01 log units), on the high side, within the range that was stated.
By their numbers in this assay, from the lowest: compounds 1, 4 and 3 (each within the scatter of the next, the first and the last beyond it).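

In this assay, hydrogen in place of fluoro on this aromatic carbon gives a 1.1-fold higher number from compound 1 to compound 4 (0.03 log units; within the scatter), so the two numbers cannot be told apart and this fluorine is not needed to hold the value. Going by these compounds alone, this is the first reading at this carbon, as the earlier step concerned the group on the aromatic nitrogen. No measurement at hand explains the result.

Still open, going by these compounds, is how an amine or a carboxylic acid on this carbon would read. Also open, on these data alone, is whether hydrogen and fluoro would again match with the 3,4-difluorophenyl group of compound 3.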